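The compounds below may be only part of what the source reports. "The series", "measured", "known", "first", "only" and "open" are said of these compounds alone.

Compound 1 `CC(C)(C)NC(=O)CCc1cccc2c1B(O)OC2` carries a tert-butyl group on an amide-type nitrogen. In a functional assay on MDA-MB-231 cells (Homo sapiens) for antiproliferative activity, read by MTT assay, with a stated time of 72 h (on this read-out higher numbers stand for weaker inhibition and lower numbers for stronger inhibition), compound 1 gives > 100000 nM, and this is a limit of the measurement rather than a number. Compound 1 is the one that sits at the limit of > 100000 nM in this assay, at which 1 of the 2 values shown sits. Compound 2 `O=C(CCc1cccc2c1B(O)OC2)Nc1ccc([N+](=O)[O-])cc1` instead carries an aromatic ring bearing a nitro group, and in this assay compound 2 gives 36000 nM. Compound 3 `O=C(CCc1cccc2c1B(O)OC2)Nc1cccc(Br)c1` is the next variation on the shared core: 3-bromophenyl in place of tert-butyl on an amide-type nitrogen. Among the compounds with values here, no measured pair shows exactly this exchange, so the step can only be judged from what the two measured compounds show. Compound 2, with its value of 36000 nM, indicates that an aromatic ring in this place brings the concentration into the measurable range. The step of an at least 2.5-fold lower number from compound 1 to compound 3 (0.39 log units; beyond the scatter) is therefore expected to be a gain beyond the usual scatter. Compound 3 is estimated at 40000 nM, with a likely range from 15000 nM to 100000 nM.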

Compound 3, half-maximal inhibitory concentration: 720 nM
Beside the measured number, compound 3's estimate is 56-fold (1.74 log units) above it, outside the stated range (below it).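

The exchange of tert-butyl for 3-bromophenyl on an amide-type nitrogen produces an at least 130-fold lower number from compound 1 to compound 3 (2.14 log units; beyond the scatter) in this assay, so the group at this position can have a large effect on the read-out. An aromatic ring alone does not set the value, since compound 2, with its nitro-bearing ring, gives 36000 nM, while compound 3 gives 720 nM. The true size of the step remains unknown, as the value for compound 1 is a limit and not a number: the limit of > 100000 nM in this assay, at which 1 of the 3 values shown sits.

Compounds 2 and 3 differ in both the ring substituent and its location, so the contribution of each remains unresolved. From the compounds shown here alone, it also remains open how an unsubstituted phenyl ring, or a chlorine atom or methoxy group in place of the bromine, would compare with compound 3.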